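Linker length and cytotoxicity: working notes toward compound 3

The source may hold more compounds than are shown below. What is called first, only, known or untested is meant among the compounds shown, and "the series" means these compounds.

Measured so far:
compound 1 `O=Cc1ccc(OCCCCCCCOc2ccc(C=O)cc2)cc1` gives 78.9%
compound 2 `O=Cc1ccc(OCCCCCCCCCCCOc2ccc(C=O)cc2)cc1` gives 94.1%

In an ADME assay on HepG2/C3A cells (Homo sapiens) for cytotoxicity, read by neutral red uptake, with a stated time of 24 h, tested at 120 uM (a lower number here means a stronger effect, a higher number a weaker effect of the compound at the concentration tested), compound 2 stands highest of the two numbers, with compound 1 the nearest and lower by a gap beyond the scatter. Compound 3 `O=Cc1ccc(OCCCCCCCCCCCCOc2ccc(C=O)cc2)cc1` differs from compound 2 by (4-formylphenoxy)methyl in place of 4-formylphenoxy on a saturated chain carbon, ten or more bonds along the chain from an oxygen on an aromatic ring. Within the data shown here, no step between measured compounds changes a single place, so the size of the coming step rests on expectation alone: compound 2 already sits near the weak end, and the change is expected to add little, giving a step of a number 0.9 percentage points higher from compound 2 to compound 3 (within the scatter) that lies within the scatter. For compound 3 the estimate is 95%, ranging from 85% to 104%.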

Compound 3, a percentage reported as activity, at one concentration (the size of the read-out at that concentration, not a potency): 89.9%
For compound 3 the middle estimate is 5.1 percentage points above the measured one; the measured number falls inside the stated range.
By their numbers in this assay, from the lowest: compound 1; then compounds 3 and 2 (each within the scatter of the next).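

In this assay, the series now has its first step that changes a single place, and it reads a number 4.2 percentage points lower from compound 2 to compound 3 (within the scatter) for (4-formylphenoxy)methyl in place of 4-formylphenoxy. At this place on the saturated chain, the change therefore gives two values that cannot be told apart at the concentration tested. Nothing available explains this result.

Open, going by these compounds, is whether a longer chain would also stay within the scatter of compound 3. Also open, on these data alone, is what a carboxylic acid or an amine in place of the formyl group would give.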